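Aryl variation on the shared core: compounds 1 to 3

The compounds below may be only part of what the source reports. "The series", "measured", "known", "first", "only" and "open" are said of these compounds alone.

Compound 1 `COc1cc2ncnc(Nc3ccc(Cl)cc3)c2cc1OCCCCC(=O)Nc1ccc(S(N)(=O)=O)cc1`: 31800 nM in a functional assay on NCI-H1975 cells (Homo sapiens) for antiproliferative activity, read by MTT assay, with a stated time of 72 h; a higher number here means a weaker inhibitor, a lower number a stronger inhibitor
Compound 2 `COc1cc2ncnc(Nc3cc(F)c(F)c(F)c3)c2cc1OCCCCC(=O)Nc1ccc(S(N)(=O)=O)cc1`: 20000 nM in this assay

Compound 2 holds the lower of the two figures, but only by a 1.6-fold lower number from compound 1 to compound 2 (0.20 log units; within the scatter). Compound 3 `COc1ccccc1Nc1ncnc2cc(OC)c(OCCCCC(=O)Nc3ccc(S(N)(=O)=O)cc3)cc12` carries 2-methoxyphenyl in place of 3,4,5-trifluorophenyl on a nitrogen on an aromatic ring. For the measured compounds named here, the single measured step, a 1.6-fold lower number from compound 1 to compound 2 (0.20 log units; within the scatter), also exchanged the aryl group on this nitrogen and stayed within the scatter; no measured step covers a 2-methoxyphenyl. A step no larger than the scatter, in no set direction, is therefore expected: a 1.3-fold higher number from compound 2 to compound 3 (0.10 log units; within the scatter). Compound 3 is estimated at 25000 nM, with a range from 8000 nM to 80000 nM.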

Compound 3, half-maximal inhibitory concentration: 8030 nM
Estimate against measurement, compound 3: 3.1-fold (0.49 log units) above, within the range that was stated.
By their numbers in this assay, from the lowest: compound 3; then compounds 2 and 1 (each within the scatter of the next).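

The aryl group on this nitrogen can shift the number in this assay beyond the scatter, which the exchange between compound 1 and compound 2 did not show: a 2.5-fold lower number from compound 2 to compound 3 (0.40 log units; beyond the scatter) and a 4.0-fold lower number from compound 1 to compound 3 (0.60 log units; beyond the scatter), both modest. Here, 2-methoxyphenyl is the entering group in each step. Nothing available explains the shift. Open, on these data alone, is whether the methoxy group itself carries the change, or whether an ethoxy group, a hydroxyl or an amine on this aryl ring would move the number further.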